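The compounds below may be only part of what the source reports. "The series", "measured", "known", "first", "only" and "open" are said of these compounds alone.

Measured so far in an ADME assay on a cell-free system (plasma, Mus musculus) for metabolic stability, read by LC-MS, tested at 2 uM; a lower number here means that the compound disappears faster, a higher number that the compound lasts longer:
compound 1, `CC(C)CNC(=O)n1c(=O)oc2cc(C3CCN(C)CC3)ccc21`: 1.33 h
compound 2, `CC(C)CNC(=O)n1c(=O)oc2cc(C3CCCCN3C)ccc21`: 0.5 h

Compound 1 holds the higher of the two half-life numbers; its nearest neighbour is compound 2, reached by a 2.7-fold lower number from compound 1 to compound 2 (0.42 log units; beyond the scatter) with 1-methylpiperidin-2-yl in place of 1-methylpiperidin-4-yl on an aromatic carbon, a modest step that lies beyond the scatter.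

Compound 3, `CN1CCC(c2ccc3c(c2)oc(=O)n3C(=O)NCCOCc2ccccc2)CC1`, is not yet measured in this assay. Relative to compound 1 the change is (benzyloxy)methyl in place of isopropyl on a saturated chain carbon bound to an amide-type nitrogen; cut one bond further out it reads isobutyl to 2-(benzyloxy)ethyl, and it sits on the saturated chain carbon bound to the amide-type nitrogen. Among the compounds with values here, no measured step touches this place: the single step between compound 1 and compound 2 alters the saturated ring on the aromatic carbon and leaves the amide side chain as it is, so it does not bear on the present change beyond showing that one modest step is the largest seen so far.

With nothing in the measured pair bearing on this position, the expectation for compound 3 in this assay is a step not clearly beyond the scatter from compound 1, a 1.3-fold lower number from compound 1 to compound 3 (0.12 log units; within the scatter), with a wide range in either direction. The estimated half-life for compound 3 is 1 h, with a range from 0.4 h to 2.5 h.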

Compound 3, half-life: 0.667 h
Compound 3: middle estimate off by 1.5-fold (0.18 log units), on the high side, and the stated range covers the measured number.
By their numbers in this assay, from the lowest: compounds 2, 3 and 1 (each within the scatter of the next, the first and the last beyond it).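

In this assay the saturated chain carbon bound to an amide-type nitrogen now has its first reading: (benzyloxy)methyl in place of isopropyl gives a 2.0-fold lower number from compound 1 to compound 3 (0.30 log units; within the scatter) and so stays within the scatter. The change is not small in atoms, with 9 heavy atoms entering for 3 and with one six-membered aromatic ring and 1 hydrogen-bond acceptor added, yet this single pair shows no clear shift in half-life at this place. Nothing available explains the half-life of compound 3 or ties it to any part of the entering group.

One pair cannot separate the contributions of the ether oxygen, the phenyl ring and the longer chain, so a plain n-butyl chain, a 2-methoxyethyl chain or a chain ending in a carboxylic acid or a tertiary amine could each read differently at this place. As far as these compounds go, it also remains open whether the same side chain behaves alike with 1-methylpiperidin-2-yl on the aromatic carbon, the change that gave a 2.7-fold lower number from compound 1 to compound 2 (0.42 log units; beyond the scatter) and so lay beyond the scatter.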